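This account rests on a few compounds, and the source may have more. Where it says the series, first, only, none or still open, it means among the compounds named here.

Working notes on the series in an ADME assay on microsomes from liver (Mus musculus) for metabolic stability, read by LC-MS, with NADPH named in the record, with a stated time of 60 min, tested at 1 uM, in the absence of a further agent; a lower number here means that less of the compound is left, a higher number that more of the compound is left. Compound 1 `COc1ccc(-c2c(C)nc3c(N4CC[C@@H](NS(=O)(=O)c5ccc(C)cc5)C4)cc(C)nn23)cc1OC` gives > 95%, which is a limit and not a number. Compound 2 `COc1ccc(-c2c(C)nc3c(N4CC[C@@H](NS(N)(=O)=O)C4)cc(C)nn23)cc1OC` gives > 95%, which is also a limit. For the measured compounds named here, the single measured step, a step that the two limits leave unreadable from compound 1 to compound 2, therefore has no readable size, and the limit of > 95% in this assay, at which 2 of the 2 values shown sit, is all the evidence available on this read-out.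

The next structure is compound 3 `COc1ccc(-c2c(C)nc3c(N4CC[C@@H](SC(C)=O)C4)cc(C)nn23)cc1OC`, with the change acetylsulfanyl in place of sulfamoylamino on a saturated ring carbon. The measured step altered only the group on the sulfonyl sulfur, whereas here the whole sulfamoylamino group leaves. That step thus offers no size to carry over, and the expectation stays loose. Compound 2 stands at a limit, so any readable move from it can only be a fall in this assay. A modest fall beyond the usual scatter is expected, while a result at the limit again remains possible. The expected step is a number at least 20 percentage points lower from compound 2 to compound 3 (beyond the scatter). The estimate for compound 3 is 75%, with an expected range of 40% to 97%.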

Compound 3, percent of the compound remaining: > 95%
Compound 3: only a limit was reported (the forecaster's own chance of this, stated with the estimate: 30%); at least 20 percentage points between middle value and limit.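

In this assay compound 3 gives > 95%, which is a limit and not a number. No new step can be read between compound 3 and either compound 1 or compound 2, and the evidence remains: the limit of > 95% in this assay, at which 3 of the 3 values shown sit. The compounds shown leave open which group on the saturated ring carbon, if any, would leave less of the compound remaining in this assay.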